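The source may report more compounds than this note shows. Statements on the series, on what has been measured and on what is new or still open speak of the compounds shown alone.

Measured so far in a functional assay on BV-2 cells (Mus musculus), read by Griess assay, with a stated time of 24 h; a lower number here means a stronger inhibitor, a higher number a weaker inhibitor:
- Compound 1 `CC1COC2(C=CC(=O)C=C2)N(c2ccccc2)C1=O`: 1220 nM
- Compound 2 `C=CCC1COC2(C=CC(=O)C=C2)N(c2ccccc2)C1=O`: 1030 nM

Going by the values given here, only these two compounds have numbers so far. Compound 2 stands level with compound 1, since their values lie within the scatter of each other and neither can be ranked above the other. The next compound, compound 3 `C=C(C)CC1COC2(C=CC(=O)C=C2)N(c2ccccc2)C1=O`, keeps the shared core and changes one place in the side chain. It has methyl in place of hydrogen on a double-bonded chain carbon bound to a saturated chain carbon, which turns allyl into 2-methylprop-2-en-1-yl (methyl in place of hydrogen on a double-bonded chain carbon bound to a saturated chain carbon).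

Among the compounds with values here, no measured pair shows this change itself. Within the data shown here, the nearest evidence is the single step at the same side chain, a 1.2-fold lower number from compound 1 to compound 2 (0.07 log units; within the scatter), and that step stayed within the scatter. On that slender basis, no shift beyond the scatter is expected in this assay, and no direction can be favoured. The expected step is a 1.0-fold lower number from compound 2 to compound 3 (0.01 log units; within the scatter). For compound 3 the estimated value is 1000 nM, with an expected range from 500 nM to 2000 nM.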

Compound 3, half-maximal inhibitory concentration: 450 nM
Compound 3: middle estimate off by 2.2-fold (0.35 log units), on the high side; the whole stated range lies above it.
By their numbers in this assay, from the lowest: compound 3; then compounds 2 and 1 (each within the scatter of the next).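

The side chain now shows a change that counts in this assay: methyl in place of hydrogen on a double-bonded chain carbon bound to a saturated chain carbon gives a step beyond the scatter (a 2.3-fold lower number from compound 2 to compound 3 (0.36 log units; beyond the scatter)), whereas the earlier step at this side chain stayed within it (a 1.2-fold lower number from compound 1 to compound 2 (0.07 log units; within the scatter)). Read as one replacement on the chain of compound 1, the 1-methylethenyl group also gives a modest step beyond the scatter (a 2.7-fold lower number from compound 1 to compound 3 (0.43 log units; beyond the scatter)), so here the vinyl group alone does not separate from compound 1 while the 1-methylethenyl group does. No measurement available here accounts for this difference between the two groups.

The compounds shown leave open whether the double bond matters at all, since a saturated isobutyl chain at this place would separate the branch from the double bond. Also open, as far as these compounds go, is whether the lower numbers continue with a larger end on the chain, such as a phenyl ring, or with an amine or a carboxylic acid there.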